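Bromophenyl for Furanyl on the Ester Series

The source may report more compounds than this note shows. Statements on the series, on what has been measured and on what is new or still open speak of the compounds shown alone.

Compound 1 `CC(C)N(Cc1cccc(OCCCCCC(=O)O)c1)C(=O)c1ccc(-c2ccoc2)cc1` — in an ADME assay on Raji cells (Homo sapiens) for cytotoxicity, read by CellTiter-Glo and resazurin assay, with a stated time of 72 h (on this read-out lower numbers stand for an effect already at smaller amounts and higher numbers for an effect only at larger amounts of compound), compound 1 gives > 26000 nM, which is a limit of the assay rather than a number.
Compound 2 `CC(C)N(Cc1cccc(OCCCCCC(=O)O)c1)C(=O)c1ccc(-c2cccc(C(F)(F)F)c2)cc1` — in this assay compound 2 gives > 26000 nM, again a limit of the assay.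
Compound 3 `CCOC(=O)CCCCCOc1cccc(CN(C(=O)c2ccc(-c3ccoc3)cc2)C(C)C)c1` — in this assay compound 3 gives > 26000 nM, once more a limit of the assay.

Compound 3 therefore stands nowhere in particular on a scale: all that is known is that it sits at the limit of > 26000 nM in this assay, at which 3 of the 3 values shown sit, and the two other values shown are the same kind of limit. The new compound is compound 4 `CCOC(=O)CCCCCOc1cccc(CN(C(=O)c2ccc(-c3cccc(Br)c3)cc2)C(C)C)c1`, which differs from compound 3 as follows: 3-bromophenyl in place of furan-3-yl on an aromatic carbon.

Going by the values given here, two measured steps touch this change. The swap of the aryl group at the same position, 3-(trifluoromethyl)phenyl in place of furan-3-yl, gave a step that the two limits leave unreadable from compound 1 to compound 2. The ester for acid exchange that leads to compound 3 gave a step that the two limits leave unreadable from compound 1 to compound 3. Neither step has a readable size or direction, so no step beyond the scatter can be expected in this assay; the expected outcome is another limit, expressed as a step that the limit leaves unreadable from compound 3 to compound 4.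

Compound 4 is estimated at 30000 nM, with a range from 13000 nM to 70000 nM, most likely reported only as the same limit.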

Compound 4, half-maximal effective concentration: > 26000 nM
Compound 4 ended at the assay's limit (the forecaster's own chance of this, stated with the estimate: 85%); the middle value does not contradict the limit.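

Compound 3 and compound 4 both end at a limit of the assay rather than at a number, so no step between them can be read in this assay: the limit of > 26000 nM in this assay, at which 4 of the 4 values shown sit.

The compounds shown leave open at which concentration any of them would have an effect in this assay, and so whether 3-bromophenyl in place of furan-3-yl changes anything there.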